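From 4-chlorophenyl to 4-bromophenyl

A few compounds are considered here, and "the series" means these few. Any claim that something is new, unique, unknown or untested is made for them only; others in the source may bear on it.

In a functional assay on A549 cells (Homo sapiens) for cytotoxicity, read by MTT assay, with a stated time of 72 h (a higher number here means a weaker inhibitor, a lower number a stronger inhibitor), compound 1 (`Cn1ccc2c(Oc3ccc(NC(=O)c4cc5cccnc5n(-c5ccccc5)c4=O)cc3)ncnc21`) gives 66200 nM and compound 2 (`Cn1ccc2c(Oc3ccc(NC(=O)c4cc5cccnc5n(-c5ccc(Cl)cc5)c4=O)cc3)ncnc21`) gives 75500 nM as its value, so these two numbers lie within the usual scatter of each other. Compound 3 (`Cn1ccc2c(Oc3ccc(NC(=O)c4cc5cccnc5n(-c5ccc(Br)cc5)c4=O)cc3)ncnc21`) differs from compound 2 at one place only, with bromo in place of chloro on an aromatic carbon. Within the data shown here, one measured step bears on this: chloro in place of hydrogen on that same carbon, which stayed within the scatter (a 1.1-fold higher number from compound 1 to compound 2 (0.06 log units; within the scatter)). With so little to go on, and with one halogen simply exchanged for another, no step beyond the scatter is expected in this assay for this swap. The estimate for compound 3 is 78000 nM with an expected range from 45000 nM to 130000 nM as its limits. That estimate means an expected step inside the scatter (a 1.0-fold higher number from compound 2 to compound 3 (0.01 log units; within the scatter)).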

Compound 3, half-maximal inhibitory concentration: 52200 nM
Estimate against measurement, compound 3: 1.5-fold (0.17 log units) above; the measured number falls inside the stated range.
By their numbers in this assay, from the lowest: compounds 3, 1 and 2 (each within the scatter of the next).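

Bromo in place of chloro on this aromatic carbon gives a 1.4-fold lower number from compound 2 to compound 3 (0.16 log units; within the scatter) in this assay and so stays within the scatter, as does bromo in place of hydrogen, with a 1.3-fold lower number from compound 1 to compound 3 (0.10 log units; within the scatter) in the same assay. Among these compounds, with a second halogen now tested at this position, hydrogen, chloro and bromo can all be compared directly, and no pair among compound 1, compound 2 and compound 3 lies beyond the scatter, so this assay does not separate these three groups. No measurement is available that could explain why these values lie so close together.

The compounds shown carry only hydrogen or a halogen at this position, so it remains open whether an amine, a carboxylic acid or a longer chain there would give a step beyond the scatter. On these data alone, whether the same holds for any other position on the shared core also remains open.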